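This account rests on a few compounds, and the source may have more. Where it says the series, first, only, none or still open, it means among the compounds named here.

Measured so far in an ADME assay on microsomes from liver (Mus musculus) for metabolic stability; a higher number here means that the compound lasts longer, a lower number that the compound disappears faster
- compound 1 `Cc1nc(C(=O)Nc2cccc(F)n2)c(C)n1-c1ccc(F)cc1` gives 0.617 h here
- compound 2 `Cc1nc(NC(=O)c2nc(C)n(-c3ccc(F)cc3)c2C)ccc1F` gives 1.43 h here

Compound 2 has the higher of these two numbers. For the measured compounds named here, the only measured step is modest, a 2.3-fold higher number from compound 1 to compound 2 (0.37 log units; beyond the scatter) on changing the group on the amide-type nitrogen. Compound 3 `Cc1nc(C(=O)Nc2ccnc(Cl)n2)c(C)n1-c1ccc(F)cc1` brings 2-chloropyrimidin-4-yl in place of 5-fluoro-6-methylpyridin-2-yl on an amide-type nitrogen at that same place. Going by the values given here, no measured compound carries 2-chloropyrimidin-4-yl, so this step is only a loose guide. Going by it, a fall of similar modest size in this assay is expected as 5-fluoro-6-methylpyridin-2-yl leaves. The expected change is a 2.4-fold lower number from compound 2 to compound 3 (0.38 log units; beyond the scatter) for this swap. Compound 3 is estimated at 0.6 h with a likely range from 0.2 h to 1.5 h in repeat measurements.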

Compound 3, half-life: 4.63 h
Estimate against measurement, compound 3: 7.7-fold (0.89 log units) below, and the stated range ends below it.
By their numbers in this assay, from the lowest: compound 1; then compound 2; then compound 3.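

In this assay the group 2-chloropyrimidin-4-yl on the amide-type nitrogen gives a 3.2-fold higher number from compound 2 to compound 3 (0.51 log units; beyond the scatter) and a 7.5-fold higher number from compound 1 to compound 3 (0.88 log units; beyond the scatter) with the rest of the molecule unchanged. This position can therefore hold a ring with two hetero atoms and a chlorine, and compound 3 stands above both fluorinated pyridine compounds. Nothing available here explains this rise.

Going by these compounds, whether the chlorine or the second ring nitrogen goes with the rise stays open. So does what an amine or a methoxy group would give in place of that chlorine.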